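Dropping a Trifluoromethyl Group: What to Expect in Cells

The compounds below may be only part of what the source reports. "The series", "measured", "known", "first", "only" and "open" are said of these compounds alone.

Measured so far:
compound 1 `COc1ccccc1-c1csc2cnc(Nc3ccc(C(=O)NC4CCNCC4)cc3C(F)(F)F)nc12`: 4110 nM
compound 2 `COc1ccccc1-c1csc2cnc(Nc3ccc(C(=O)NC4CCOCC4)c(F)c3)nc12`: 5710 nM

Of the compounds shown here, two have been tested in a functional assay on A549 cells (Homo sapiens) for inhibition, read by MTT assay, with a stated time of 72 h; a higher number here means a weaker inhibitor, a lower number a stronger inhibitor. Compound 1 gives 4110 nM, the lowest of the two numbers. Compound 2 gives 5710 nM, which lies within the usual scatter of the value for compound 1, so the two cannot be ranked against each other. Among the compounds with values here, the two compounds also differ from each other in several places at once, so no single-change step between measured compounds is available to guide a prediction.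

The unmeasured compound 3 `COc1ccccc1-c1csc2cnc(Nc3ccc(C(=O)NC4CCNCC4)cc3)nc12` differs from compound 1 in a single place: hydrogen in place of trifluoromethyl on an aromatic carbon. With no measured step of this kind in hand, the size of the change can only be guessed. The expectation is a modest step in the direction of a weaker inhibitor, of a size that may not exceed the scatter, expressed as a 1.6-fold higher number from compound 1 to compound 3 (0.20 log units; within the scatter). Compound 3 is therefore estimated at 6500 nM in this assay, with a likely range from 2500 nM to 17000 nM.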

Compound 3, half-maximal inhibitory concentration: 360 nM
Compound 3: middle estimate off by 18-fold (1.26 log units), on the high side, outside the stated range (below it).
By their numbers in this assay, from the lowest: compound 3; then compounds 1 and 2 (each within the scatter of the next).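

Replacing trifluoromethyl with hydrogen in this assay gives an 11-fold lower number from compound 1 to compound 3 (1.06 log units; beyond the scatter), a large step well beyond the scatter. Within the data shown here, this is the first single-change comparison, and it shows that this position, on a six-membered aromatic ring of carbon only, ortho to a large group and meta to a (piperidin-4-yl)carbamoyl group, is far from a neutral spot: losing these 4 heavy atoms, with nothing but a hydrogen atom entering, is enough to move the cell result strongly towards a stronger inhibitor. Nothing measured here explains why the number falls, so the step stands as an observation and not as an explanation.

The compounds shown leave open how other groups at this same position, such as a methyl, a chlorine or a methoxy group, would behave, and so whether the result is driven by the loss of trifluoromethyl in particular or whether any group at this position would raise the number. On these data alone, this is also a single pair in a single cell assay, so it remains open whether a step of this size would recur with a different group on the amide nitrogen.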